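A few compounds are considered here, and "the series" means these few. Any claim that something is new, unique, unknown or untested is made for them only; others in the source may bear on it.

Measured compounds in a physicochemical assay for lipophilicity; a lower number here means a more polar compound, a higher number a more lipophilic compound:
Compound 1 `CCC(=O)Oc1c(OC)c(OC)c(OC(=O)CC)c2c(OC)cccc12` gives 3.44.
Compound 2 `COc1c(OC)c(OC(=O)C(C)(C)C)c2c(OC)cccc2c1OC(=O)C(C)(C)C` gives 5.6.
Compound 3 `CCC(=O)Oc1c(OC)c(OC)c(OC(=O)CC)c2c(C)cccc12` gives 3.9.

Compound 1 and compound 3 share a core and differ in one place: methyl in place of methoxy on an aromatic carbon. In this assay this gave a number 0.46 log units higher from compound 1 to compound 3 (beyond the scatter). Compound 2 stands above both of them in this assay; its value lies beyond the scatter from that of compound 3 and further still from that of compound 1. The difference between the core of compound 2 and the core of compound 1 is not broken down here.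

Compound 4 `COc1c(OC)c(OC(=O)C(C)(C)C)c2c(C)cccc2c1OC(=O)C(C)(C)C` has not yet been measured. It differs from compound 2 in one place: methyl in place of methoxy on an aromatic carbon. Among the compounds with values here, this is the same change as the one from compound 1 to compound 3, at the same kind of place. The step is therefore expected to be similar, about a number 0.45 log units higher from compound 2 to compound 4 (beyond the scatter) in this assay, because the measured pair gave a number 0.46 log units higher from compound 1 to compound 3 (beyond the scatter). On that basis compound 4 is estimated at 6.05 in this assay, with an expected range from 5.65 to 6.45.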

Compound 4, partition coefficient: 6.1
For compound 4 the middle estimate is 0.05 log units below the measured one, within the range that was stated.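

In this assay the replacement of methoxy by methyl gave a number 0.50 log units higher from compound 2 to compound 4 (beyond the scatter), much the same size as the step on the other core, a number 0.46 log units higher from compound 1 to compound 3 (beyond the scatter). The change therefore carried over between these two cores in direction and in approximate size, even though compound 2 already stands well above compound 1 in this assay, but two matched pairs show only this one transfer and establish no rule for the series or for other cores. Nothing presented here explains why the step has this size or why it is similar on both cores.

The compounds shown leave open whether the same step would appear at another aromatic carbon, or on a core carrying a different substituent such as an amine or a carboxylic acid. They also leave open how a group other than methyl, such as ethyl or a longer chain, would compare with methoxy at this place.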